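The source may report more compounds than this note shows. Statements on the series, on what has been measured and on what is new or still open speak of the compounds shown alone.

In a functional assay (blood) for inhibition, with Homo sapiens as the target (a higher number here means a weaker inhibitor, a lower number a stronger inhibitor), compound 1, `CC(C)(C)Sc1c(CC(C)(C)C(=O)O)n(Cc2ccc(Cl)cc2)c2ccc(OCc3ccc4cc(F)ccc4n3)cc12`, gives 880 nM. Compound 2, `Cc1nc2ccc(COc3ccc4c(c3)c(SC(C)(C)C)c(CC(C)(C)C(=O)O)n4Cc3ccc(Cl)cc3)cc2s1`, gives only a limit of the assay, > 3000 nM, and no number.

Compound 3, `CC(C)(C)Sc1c(CC(C)(C)C(=O)O)n(Cc2ccc(Cl)cc2)c2ccc(OCc3nc4ccccc4o3)cc12`, carries 1,3-benzoxazol-2-yl in place of 2-methyl-1,3-benzothiazol-6-yl on a saturated chain carbon bound to an oxygen on an aromatic ring.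

Among the measured compounds shown here, one measured step bears on this place. With 2-methyl-1,3-benzothiazol-6-yl in place of 6-fluoroquinolin-2-yl, an at least 3.4-fold higher number from compound 1 to compound 2 (0.53 log units; beyond the scatter) lies beyond the scatter, so this assay does respond to the group here. That single step gives no rule for the new group, and the limit leaves the starting point open. A modest move to a lower number is expected, though another limit remains possible.

The expected step is an at least 1.6-fold lower number from compound 2 to compound 3 (0.22 log units; that floor lies within the scatter). For compound 3 the estimated value is 1800 nM, with an expected range of 500 nM to 5000 nM.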

Compound 3, half-maximal inhibitory concentration: 2500 nM
Compound 3: the middle estimate sits 1.4-fold (0.14 log units) below what was measured; measured number inside the range.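

In this assay, 1,3-benzoxazol-2-yl on the saturated chain carbon bound to an oxygen on an aromatic ring gives a second replacement for 6-fluoroquinolin-2-yl that does not hold the level of compound 1, with a 2.8-fold higher number from compound 1 to compound 3 (0.45 log units; beyond the scatter). Against 2-methyl-1,3-benzothiazol-6-yl the change shows an at least 1.2-fold lower number from compound 2 to compound 3 (0.07 log units; that floor lies within the scatter), so no order between these two groups can be claimed. Compound 2 stands at a limit and not at a number: the limit of > 3000 nM in this assay, at which 1 of the 3 values shown sits.

As far as these compounds go, how quinolin-2-yl without the fluorine, or a plain phenyl, would read at this place remains open. Also open is whether any group here gives a lower number than 6-fluoroquinolin-2-yl, since both replacements shown lie on the higher side of compound 1.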